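Trimming the nitrooxy ester chain of compound 1

The source may hold more compounds than are shown below. What is called first, only, known or untested is meant among the compounds shown, and "the series" means these compounds.

Compound 1 (`COc1cc(/C=C/C(=O)OCCCCCCO[N+](=O)[O-])ccc1O`): > 50000 nM (a limit)
Compound 2 (`O=C(/C=C/c1ccc(OCCCCO[N+](=O)[O-])c(O)c1)OCCCCO[N+](=O)[O-]`): > 50000 nM (a limit)

In a functional assay on Calu-1 cells (Homo sapiens) for cytotoxicity, read by resazurin assay, with a stated time of 72 h (on this read-out higher numbers stand for weaker inhibition and lower numbers for stronger inhibition), compound 1 gives > 50000 nM, which is a limit of the assay and not a number. Compound 2 also gives only a limit in this assay, namely > 50000 nM. Neither compound therefore offers a measured potency as a starting point (the limit of > 50000 nM in this assay, at which 2 of the 2 values shown sit).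

The next compound, compound 3 (`COc1cc(/C=C/C(=O)OCCCCCO[N+](=O)[O-])ccc1O`), differs from compound 1 in one place on the ester chain (nitrooxy in place of (nitrooxy)methyl on a saturated chain carbon, five bonds along the chain from an oxygen next to a carbonyl group). Nitrooxy stands in place of (nitrooxy)methyl on a saturated chain carbon, five bonds along the chain from an oxygen next to a carbonyl group.

Among the compounds with values here, no measured pair shows what this kind of change does. The expectation in this assay is therefore no step beyond the usual scatter and no firm direction, with the limit of compound 1 (> 50000 nM) as the only anchor. The estimated step is a number no higher from compound 1 to compound 3 (the limit leaves the size open). Compound 3 is expected at 50000 nM, with an estimated range from 25000 nM to 100000 nM, and the assay may well report only a limit again.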

Compound 3, half-maximal inhibitory concentration: 26300 nM
Compound 3: the middle estimate sits 1.9-fold (0.28 log units) above what was measured, and the stated range covers the measured number.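

In this assay, putting nitrooxy in place of (nitrooxy)methyl on this saturated chain carbon gives an at least 1.9-fold lower number from compound 1 to compound 3 (0.27 log units; that floor lies within the scatter). Within the data shown here, this is the first sign that the ester chain can be altered at this place and still yield a real number, since compound 3 reads as a measured value and not as a limit. Even so, the true size of the step remains unknown, and the smallest step the data allow does not clear the scatter, because compound 1 offers only a limit as its partner in the comparison: the limit of > 50000 nM in this assay, at which 2 of the 3 values shown sit.

The compounds shown leave open whether the trend, if there is one, would carry on along the chain, for instance with a still shorter ester chain ending in a 4-(nitrooxy)butyl group, or would reverse with a longer one. They also cannot tell whether the nitrooxy group itself matters for the value of compound 3, a question that an amine or a carboxylic acid at the same chain carbon would help to answer.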